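This account rests on a few compounds, and the source may have more. Where it says the series, first, only, none or still open, it means among the compounds named here.

Of the compounds shown here, three built on one shared core have been measured in a functional assay on A549 cells (Homo sapiens) for inhibition, read by MTT assay, with a stated time of 72 h; on this read-out lower numbers stand for stronger inhibition and higher numbers for weaker inhibition. Compound 1 `CN(C(=O)NC(=O)c1ccc(C(F)(F)F)cc1)c1nc(C(F)(F)F)c(C(=O)N/N=C/c2cccc(C(F)(F)F)c2)s1` gives 6.66 ug/mL, the lowest of the three numbers. Compound 3 `CN(C(=O)NC(=O)c1cccc(C(F)(F)F)c1)c1nc(C(F)(F)F)c(C(=O)N/N=C/c2cccc(C(F)(F)F)c2)s1` gives 8.16 ug/mL, and the step of a 1.2-fold higher number from compound 1 to compound 3 (0.09 log units; within the scatter) stays within the scatter, so these two cannot be ranked. Compound 2 `CN(C(=O)NC(=O)c1ccccc1F)c1nc(C(F)(F)F)c(C(=O)N/N=C/c2cccc(C(F)(F)F)c2)s1` gives 19.5 ug/mL, and the step of a 2.9-fold higher number from compound 1 to compound 2 (0.47 log units; beyond the scatter) lies beyond the scatter. Compound 4 `CN(C(=O)NC(=O)c1ccc(C(F)(F)F)cc1)c1nc(C(F)(F)F)c(C(=O)N/N=C/c2ccccc2C(F)(F)F)s1` differs from compound 1 by 2-(trifluoromethyl)phenyl in place of 3-(trifluoromethyl)phenyl on a carbon with a double bond to nitrogen. Within the data shown here, none of the measured steps touches this part of the molecule; all three alter the group on the carbonyl carbon instead, where a 1.2-fold higher number from compound 1 to compound 3 (0.09 log units; within the scatter) shows that shifting a trifluoromethyl to another place on its ring changed the number only within the scatter. A similarly small step is therefore expected, a 1.3-fold higher number from compound 1 to compound 4 (0.11 log units; within the scatter). Compound 4 is estimated to give 8.5 ug/mL, within the range 4 ug/mL to 18 ug/mL.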

Compound 4, half-maximal inhibitory concentration: 6.68 ug/mL
Compound 4: middle estimate off by 1.3-fold (0.10 log units), on the high side, within the range that was stated.
By their numbers in this assay, from the lowest: compounds 1, 4 and 3 (each within the scatter of the next); then compound 2.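

Swapping 3-(trifluoromethyl)phenyl for 2-(trifluoromethyl)phenyl on the carbon with a double bond to nitrogen is the first measured change at this place, and in this assay it gives a 1.0-fold higher number from compound 1 to compound 4 (0.00 log units; within the scatter). On this read-out, the two arrangements of the trifluoromethyl group at this place cannot be told apart. No available evidence explains this result.

As far as these compounds go, both compounds carry a trifluoromethyl on this ring, so the effect of replacing it remains open. An unsubstituted phenyl, or a ring bearing an amine or a carboxylic acid, could test whether this group matters here.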